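From 3-methoxyphenyl to 4-methoxyphenyl in the series

A few compounds are considered here, and "the series" means these few. Any claim that something is new, unique, unknown or untested is made for them only; others in the source may bear on it.

In an ADME assay on BJ cells (Homo sapiens) for cytotoxicity, read by MTT assay, with a stated time of 72 h (a higher number here means a weaker inhibitor, a lower number a stronger inhibitor), compound 1 `Oc1cccc(CNc2ncnc3c2ncn3C2CCCO2)c1` gives > 100000 nM as a limit of the assay. Compound 2 `COc1cccc(CNc2ncnc3c2ncn3C2CCCO2)c1` gives > 100000 nM as a limit too, which places it at the limit of > 100000 nM in this assay, at which 2 of the 2 values shown sit, and not on a number. Compound 3 `COc1ccc(CNc2ncnc3c2ncn3C2CCCO2)cc1` differs from compound 2 thus: 4-methoxyphenyl in place of 3-methoxyphenyl on a saturated chain carbon bound to a nitrogen on an aromatic ring. Within the data shown here, the only measured step bearing on this is a step that the two limits leave unreadable from compound 1 to compound 2 and it offers no size to carry over. No step beyond the scatter is therefore expected in this assay, in either direction. The expected step is a number no higher from compound 2 to compound 3 (the limit leaves the size open) by estimate. For compound 3 the estimated value is 100000 nM, with an expected range of 50000 nM to 200000 nM, and a further limit is likely.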

Compound 3, half-maximal inhibitory concentration: > 100000 nM
Compound 3 was reported as a limit (the forecaster's own chance of this, stated with the estimate: 85%); the middle value lies on the limit itself.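

No step can be read between compound 1, compound 2 and compound 3 in this assay, as all three stand at one limit: the limit of > 100000 nM in this assay, at which 3 of the 3 values shown sit. The compounds shown leave open what number, if any, the read-out would give for each.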